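Methylamino in Place of Trifluoromethyl on the Anilino Methylphenyl

The source may hold more compounds than are shown below. What is called first, only, known or untested is meant among the compounds shown, and "the series" means these compounds.

Compound 3 `Cc1ccc(NC(=O)c2cccc(C(F)(F)F)c2)cc1N1Cc2cnc(Nc3ccc(C)c(C(F)(F)F)c3)nc2N(C)C1=O` gives 29 nM in a functional assay on K562 cells (Homo sapiens) for antiproliferative activity, read by CellTiter-Glo and CCK-8 assay, with a stated time of 72 h (a higher number here means a weaker inhibitor of growth, a lower number a stronger inhibitor of growth), the top of three numbers, though the step from compound 2 `Cc1ccc(Nc2ncc3c(n2)N(C)C(=O)N(c2cc(NC(=O)c4cccc(C(F)(F)F)c4)ccc2C)C3)cc1` is a 1.6-fold higher number from compound 2 to compound 3 (0.21 log units; within the scatter) and the step from compound 1 `Cc1ccc(Nc2ncc3c(n2)N(C)C(=O)N(c2cc(NC(=O)c4cccc(C(F)(F)F)c4)ccc2C)C3)cc1C` is a 1.7-fold higher number from compound 1 to compound 3 (0.23 log units; within the scatter), both within the scatter. In this assay compound 2 gives 18 nM and compound 1 gives 17 nM. Compound 4 `CNc1cc(Nc2ncc3c(n2)N(C)C(=O)N(c2cc(NC(=O)c4cccc(C(F)(F)F)c4)ccc2C)C3)ccc1C` is not yet measured; it differs from compound 3 by methylamino in place of trifluoromethyl on an aromatic carbon. The measured steps at this position, a 1.7-fold higher number from compound 1 to compound 3 (0.23 log units; within the scatter) and a 1.6-fold higher number from compound 2 to compound 3 (0.21 log units; within the scatter), were both within the scatter, and none covers methylamino. No step beyond the scatter is therefore expected in this assay; the expected step is a 1.5-fold lower number from compound 3 to compound 4 (0.16 log units; within the scatter). Compound 4 is estimated at 20 nM, ranging from 7 nM to 60 nM.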

Compound 4, concentration for 50% growth inhibition: 19 nM
Estimate against measurement, compound 4: 1.1-fold (0.02 log units) above, and the stated range covers the measured number.
By their numbers in this assay, from the lowest: compounds 1, 2, 4 and 3 (each within the scatter of the next).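

Methylamino, which brings a hydrogen-bond donor that trifluoromethyl lacks, still leaves this assay unmoved: the result is a 1.5-fold lower number from compound 3 to compound 4 (0.18 log units; within the scatter) against trifluoromethyl, a 1.1-fold higher number from compound 2 to compound 4 (0.02 log units; within the scatter) against hydrogen and a 1.1-fold higher number from compound 1 to compound 4 (0.05 log units; within the scatter) against methyl, all within the scatter. Across these four groups, the position has therefore produced no step beyond the scatter. Nothing available bears on this result.

Going by these compounds, whether dimethylamino, a carboxylic acid or a longer chain at this position would also stay within the scatter remains open.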